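This account rests on a few compounds, and the source may have more. Where it says the series, first, only, none or still open, it means among the compounds named here.

Three related compounds have been tested in a functional assay on HepG2 cells (Homo sapiens) for cytotoxicity, read by MTT assay, with a stated time of 48 h; a higher number here means a weaker inhibitor, a lower number a stronger inhibitor: compound 1 (`COc1ccc2c(c1)C(C)=CC(C)(C)N2Cc1cn(Cc2cc3cc(OC)ccc3nc2Cl)nn1`) gives 27200 nM, compound 2 (`CC1=CC(C)(C)N(Cc2cn(Cc3cc4cc(C)ccc4nc3Cl)nn2)c2ccccc21`) gives 23000 nM, and compound 3 (`CC1=CC(C)(C)N(Cc2cn(Cc3cc4ccc(C)cc4nc3Cl)nn2)c2ccccc21`) gives 26200 nM. Compound 1 therefore stands level with the other two, since its number lies within the usual scatter of repeated measurements from both, and none of the three can be called stronger or weaker.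

Compound 4 (`COc1ccc2nc(Cl)c(Cn3cc(CN4c5ccc(C)cc5C(C)=CC4(C)C)nn3)cc2c1`) has not been measured yet. It differs from compound 1 in a single place, with methyl in place of methoxy on an aromatic carbon. Among the compounds with values here, no two measured compounds differ in only one place, so this swap has no direct precedent here. Even so, compound 1 at 27200 nM and compound 2 at 23000 nM differ in more than one place and remain within the scatter, so in this assay no step beyond the scatter is expected, in either direction. The estimated step is a 1.1-fold lower number from compound 1 to compound 4 (0.04 log units; within the scatter). For compound 4 the expected value is 25000 nM, with an estimated range from 15000 nM to 40000 nM.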

Compound 4, half-maximal inhibitory concentration: 21600 nM
The estimate for compound 4 lay 1.2-fold (0.06 log units) above the measured number; low and high end bracket the measured number.
By their numbers in this assay, from the lowest: compounds 4, 2, 3 and 1 (each within the scatter of the next).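

Methyl in place of methoxy on this aromatic carbon gives the first comparison here between two compounds that differ in only one place: in this assay, the step is a 1.3-fold lower number from compound 1 to compound 4 (0.10 log units; within the scatter). The earlier compounds shown here could not isolate this position, but this pair shows that the swap, which removes one oxygen atom and one hydrogen-bond acceptor, leaves the reading level with that of compound 1. No measurement on hand explains why these two groups read alike.

As far as these compounds go, whether an amine, a carboxylic acid or a longer chain on this same carbon would also leave the reading within the scatter remains open. Also open, from the compounds shown here alone, is whether the methoxy that compound 4 keeps elsewhere in its structure would tolerate the same swap.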